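Series notes: aryl exchange on the ring amine nitrogen

The source may report more compounds than this note shows. Statements on the series, on what has been measured and on what is new or still open speak of the compounds shown alone.

Measured so far:
compound 1, `CCCn1c(=O)[nH]c2nc(-c3ccc(S(=O)(=O)N4CCN(c5ccc(Br)cc5)CC4)cc3)[nH]c2c1=O`: 29%
compound 2, `CCCn1c(=O)[nH]c2nc(-c3ccc(S(=O)(=O)N4CCN(c5ccc(C)cc5)CC4)cc3)[nH]c2c1=O`: 25%

In an assay on CHO cells for displacement of a labelled ligand from adenosine receptor A3 (Homo sapiens), read by scintillation counting, with a stated time of 45 min, tested at 1 uM, in the presence of a further agent that is not named here (on this read-out lower numbers stand for less inhibition and higher numbers for more inhibition at the one concentration tested (going by the name of the read-out)), compound 1 gives 29%. Compound 2 gives 25%. Among the compounds with values here, compound 2 carries the smaller of the two numbers, but the single step that leads to it, a number 4 percentage points lower from compound 1 to compound 2 (within the scatter), lies within the scatter, so the two compounds cannot be told apart on this read-out.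

Compound 3, `CCCn1c(=O)[nH]c2nc(-c3ccc(S(=O)(=O)N4CCN(c5cccc(F)c5)CC4)cc3)[nH]c2c1=O`, is not yet measured. It differs from compound 2 by 3-fluorophenyl in place of 4-methylphenyl on an amine nitrogen in a ring. Within the data shown here, the one measured step bears on this change only loosely: it exchanged one substituent on the aromatic ring carried by the ring amine nitrogen, and the result, a number 4 percentage points lower from compound 1 to compound 2 (within the scatter), stayed within the scatter. Among the measured compounds shown here, the step to compound 3 exchanges the whole aromatic group at the same position, for which no measured pair exists. For the measured compounds named here, with the only comparison showing no movement beyond the scatter, no step beyond the scatter is expected in this assay either, in either direction.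

For compound 3 the expected value in this assay is 27%, with a range of 12% to 42%. The step this estimate implies, a number 2 percentage points higher from compound 2 to compound 3 (within the scatter), is expected to stay within the scatter.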

Compound 3, a percentage reported as inhibition, at one concentration (the size of the read-out at that concentration, not a potency): 44%
Estimate against measurement, compound 3: 17 percentage points below; the whole stated range lies below it.
By their numbers in this assay, from the lowest: compounds 2 and 1 (each within the scatter of the next); then compound 3.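

In this assay, the aromatic group on the amine nitrogen in the ring now produces a step beyond the scatter, which the exchange between compound 1 and compound 2 did not: 3-fluorophenyl in place of 4-methylphenyl gives a number 19 percentage points higher from compound 2 to compound 3 (beyond the scatter), and 3-fluorophenyl in place of 4-bromophenyl gives a number 15 percentage points higher from compound 1 to compound 3 (beyond the scatter). Both steps are modest, yet they place compound 3 clear of both earlier compounds, so this position does respond to the aromatic group it carries, even though the 4-bromophenyl and 4-methylphenyl groups cannot be told apart here. The groups exchanged match in heavy-atom count and in their hydrogen-bond donor and acceptor counts, so those counts do not separate them, and no supporting data are available to account for the step.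

The change alters both the substituent and its place on the aromatic ring, so these compounds cannot show which of the two carries the step. A 4-fluorophenyl or 3-methylphenyl group would separate the two, while an unsubstituted phenyl or a pyridyl group would show whether any substituent on this aromatic group is needed.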